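Aryl swap on the triazole of the dibenzyloxy lactone series

The source may report more compounds than this note shows. Statements on the series, on what has been measured and on what is new or still open speak of the compounds shown alone.

The shared core carries a triazole through a hydroxylated linker in compound 1 `O=C1O[C@H]([C@@H](O)Cn2cc(-c3cc(C(F)(F)F)cc(C(F)(F)F)c3)nn2)C(OCc2ccccc2)=C1OCc1ccccc1` and compound 3 `O=C1O[C@H]([C@@H](O)Cn2cc(CNS(=O)(=O)c3ccc(F)cc3)nn2)C(OCc2ccccc2)=C1OCc1ccccc1`, whereas compound 2 `O=C1O/C(=C\Cn2cc(-c3cc(F)cc(F)c3)nn2)C(OCc2ccccc2)=C1OCc1ccccc1` joins its triazole through an unsaturated linker. In a functional assay on A549 cells (Homo sapiens) for antiproliferative activity, read by MTT assay, with a stated time of 72 h (on this read-out lower numbers stand for stronger inhibition and higher numbers for weaker inhibition), compound 3 gives 22500 nM, the lowest of the two numbers recorded. Compound 1 gives 28900 nM, which lies within the scatter of compound 3, so no order between the two can be read. Compound 2 reaches only a limit of the assay, > 100000 nM. One of the three values thus sits at the limit of > 100000 nM in this assay, at which 1 of the 3 values shown sits.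

Compound 4 `O=C1O[C@H]([C@@H](O)Cn2cc(-c3cc(F)cc(F)c3)nn2)C(OCc2ccccc2)=C1OCc1ccccc1` differs from compound 3 in one place: 3,5-difluorophenyl in place of (((4-fluorophenyl)sulfonyl)amino)methyl on an aromatic carbon. Among the compounds with values here, no measured pair in this set shares that change, so the expectation rests on neighbours. Compound 1, with a different fluorinated aryl on the same five-membered aromatic ring with three nitrogens, gives 28900 nM on the same linker. Compound 2 carries the 3,5-difluorophenyl of compound 4 but on the unsaturated linker and stays at a limit. A weakening step of modest size is expected from compound 3 to compound 4, a 1.8-fold higher number from compound 3 to compound 4 (0.25 log units; within the scatter). Compound 4 is therefore estimated at 40000 nM, with a range from 15000 nM to 120000 nM.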

Compound 4, half-maximal inhibitory concentration: 41200 nM
Beside the measured number, compound 4's estimate is 1.0-fold (0.01 log units) below it, within the range that was stated.
By their numbers in this assay, from the lowest: compounds 3, 1 and 4 (each within the scatter of the next). At a limit, above all of these: compound 2.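

On the hydroxylated linker, the aromatic carbon of the five-membered aromatic ring with 3 nitrogen accepts a large exchange of groups in this assay: 3,5-difluorophenyl in place of (((4-fluorophenyl)sulfonyl)amino)methyl gives a 1.8-fold higher number from compound 3 to compound 4 (0.26 log units; within the scatter). The exchange loses the hydrogen-bond donor and acceptors of the leaving group and its sulfonyl amino link, yet the step stays within the scatter, so this pair gives no sign that these features matter at this position in this assay. The 3,5-difluorophenyl group can now be read on both linkers, and compound 2, which carries it on the unsaturated linker, sits at a limit of the assay, unlike compound 4: the limit of > 100000 nM in this assay, at which 1 of the 4 values shown sits.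

The limit of compound 2 gives no size for the linker change, and the step on the hydroxylated linker is too small to set an order between the two groups. As far as these compounds go, whether an amine, a carboxylic acid or a longer alkyl chain on this aromatic carbon would move the number beyond the scatter remains open.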